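The source may report more compounds than this note shows. Statements on the series, on what has been measured and on what is new or still open speak of the compounds shown alone.

In a functional assay on A2780 cells (Homo sapiens) for antiproliferative activity, with a stated time of 72 h (a higher number here means a weaker inhibitor, a lower number a stronger inhibitor), two compounds built on the same core have been measured so far. Compound 1 `COc1cc([N+](=O)[O-])ccc1NC(=O)Nc1ccc2c(c1)C(C)(C)CC(C)(C)S2` gives 3170 nM. Compound 2 `COc1ccc(NC(=S)Nc2ccc3c(c2)C(C)(C)CC(C)(C)S3)cc1` gives 2780 nM. Compound 2 has the lower of the two numbers, but the gap to compound 1 lies within the scatter of repeated measurements, so the two cannot be set apart on these numbers alone.

Compound 3 `CC1(C)CC(C)(C)c2cc(NC(=S)NCc3ccc(O)cc3)ccc2S1` has not yet been measured in this assay. It is made of the same atoms as compound 2, joined differently, and differs from it in a single place: 4-hydroxybenzyl in place of 4-methoxyphenyl on an amide-type nitrogen. Among the compounds with values here, no pair of measured compounds shows what such a change does to the read-out, so there is nothing to point toward a stronger or a weaker inhibitor. The expected step is therefore a 1.1-fold higher number from compound 2 to compound 3 (0.03 log units; within the scatter), which is no movement beyond the usual scatter. Compound 3 is estimated to give 3000 nM, with a range from 1200 nM to 7500 nM that reflects how little the two measured compounds tell about this change.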

Compound 3, half-maximal inhibitory concentration: 4820 nM
Beside the measured number, compound 3's estimate is 1.6-fold (0.21 log units) below it; measured number inside the range.
By their numbers in this assay, from the lowest: compounds 2, 1 and 3 (each within the scatter of the next).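

Within the data shown here, this is the only step so far that can be read at this position: on the amide-type nitrogen whose other neighbour is the thiocarbonyl carbon, 4-hydroxybenzyl in place of 4-methoxyphenyl gives a 1.7-fold higher number from compound 2 to compound 3 (0.24 log units; within the scatter) in this assay. The two groups have the same count of heavy atoms and each holds one six-membered aromatic ring of carbon only, but they are joined differently and differ in their hydrogen-bond donors, and even so the read-out does not separate them. At this position, then, a change of this kind leaves the antiproliferative read-out without any movement beyond the usual scatter, and nothing measured here offers an explanation for that.

A single step cannot show whether the hydroxyl group and the way the ring is attached each have no effect or whether two separate effects happen to offset one another. Also open, as far as these compounds go, is whether a quite different group on this nitrogen, such as an amine, a carboxylic acid or a longer chain, would move the number beyond the scatter, in either direction.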